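Amide aryl variation on a shared chromone-type core

The source may hold more compounds than are shown below. What is called first, only, known or untested is meant among the compounds shown, and "the series" means these compounds.

Compound 1 `O=C(Nc1cccc(-c2oc3cc(-c4ccc(F)cc4)ccc3c(=O)c2O)c1)c1ccccc1F`, compound 2 `O=C(Nc1cccc(-c2oc3cc(-c4ccc(F)cc4)ccc3c(=O)c2O)c1)c1ccc(F)cc1F` and compound 3 `COc1ccccc1C(=O)Nc1cccc(-c2oc3cc(-c4ccc(F)cc4)ccc3c(=O)c2O)c1` share one core and differ only in the aryl group on the amide carbonyl. In a functional assay on HepG2 cells (Homo sapiens) for antiproliferative activity, read by CCK-8 assay, with a stated time of 72 h (on this read-out lower numbers stand for stronger inhibition and higher numbers for weaker inhibition), compound 1 gives 10100 nM, compound 2 gives 26400 nM and compound 3 gives 14500 nM. Compound 3 stands second highest of the three: a 1.4-fold higher number from compound 1 to compound 3 (0.16 log units; within the scatter) and a 1.8-fold lower number from compound 2 to compound 3 (0.26 log units; within the scatter); only a 2.6-fold higher number from compound 1 to compound 2 (0.42 log units; beyond the scatter) lies beyond the scatter. Compound 4 `COc1cc(OC)cc(C(=O)Nc2cccc(-c3oc4cc(-c5ccc(F)cc5)ccc4c(=O)c3O)c2)c1` is the next member: 3,5-dimethoxyphenyl in place of 2-methoxyphenyl on a carbonyl carbon. Within the data shown here, the steps that bear on this change are the two touching the amide aryl of compound 3, both within the scatter, so no step beyond the scatter is expected in this assay in either direction. Compound 4 is therefore estimated at 15000 nM, within 6000 nM to 40000 nM. The expected step is a 1.0-fold higher number from compound 3 to compound 4 (0.01 log units; within the scatter).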

Compound 4, half-maximal inhibitory concentration: 23500 nM
Estimate against measurement, compound 4: 1.6-fold (0.19 log units) below, and the stated range covers the measured number.
By their numbers in this assay, from the lowest: compounds 1, 3, 4 and 2 (each within the scatter of the next, the first and the last beyond it).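

In this assay, 3,5-dimethoxyphenyl on the amide carbonyl does not separate from 2-methoxyphenyl (a 1.6-fold higher number from compound 3 to compound 4 (0.21 log units; within the scatter)) or from 2,4-difluorophenyl (a 1.1-fold lower number from compound 2 to compound 4 (0.05 log units; within the scatter)). Like 2,4-difluorophenyl, it lies beyond the scatter of 2-fluorophenyl (a 2.3-fold higher number from compound 1 to compound 4 (0.37 log units; beyond the scatter)), so compound 1 now separates from two members while compound 3 separates from none. Nothing measured on these compounds accounts for these differences. From the compounds shown here alone, whether a basic amine or a carboxylic acid on this aryl ring, or a pyridine in its place, would leave this narrow range remains open.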